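The compounds below may be only part of what the source reports. "The series", "measured", "known", "first", "only" and "open" are said of these compounds alone.

Compound 1 `Fc1ccc(C2=CC3CNCC(C2)C3)cn1` gives 85 nM in an in vitro functional assay on SH-EP1 cells for agonist activity at Neuronal acetylcholine receptor; alpha4/beta2 (Homo sapiens), read by FLIPR and calcium flux; a lower number here means that less compound is needed, a higher number that more compound is needed for the effect. Compound 2 `C1=C(c2cncnc2)CC2CNCC1C2` gives 162 nM in this assay. Compound 3 `CN1CC2C=C(c3ccc(F)nc3)CC(C2)C1` reaches only a limit of the assay, > 10000 nM in this assay.

Among the compounds with values here, compound 3 thus stands at the limit of > 10000 nM in this assay, at which 1 of the 3 values shown sits, the one value of the three that is not a number. Within the data shown here, the step of an at least 110-fold higher number from compound 1 to compound 3 (2.07 log units; beyond the scatter) is the only measured change, and it touches compound 3 only through the methyl that compound 3 keeps. Among the measured compounds shown here, no measured step concerns the change from compound 3 to compound 4, (methoxy in place of fluoro on an aromatic carbon), which yields compound 4 `COc1ccc(C2=CC3CC(C2)CN(C)C3)cn1`. With compound 3 already at the limit, compound 4 is expected to stay beyond it, a step that the limit leaves unreadable from compound 3 to compound 4 in this assay that cannot be set against the scatter. Compound 4 is therefore estimated at 15000 nM, between 3000 nM and 100000 nM.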

Compound 4, half-maximal effective concentration: > 10000 nM
Compound 4 was reported as a limit; the forecaster's own chance of this, stated with the estimate: 75%; the middle value lies beyond the limit too.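

The step between compound 3 and compound 4 cannot be read, since both stand at a limit of the assay: the limit of > 10000 nM in this assay, at which 2 of the 4 values shown sit. The compounds shown leave open what methoxy in place of fluoro does when hydrogen, not methyl, sits on the amine nitrogen in the ring.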